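A few compounds are considered here, and "the series" means these few. Any claim that something is new, unique, unknown or untested is made for them only; others in the source may bear on it.

Three anilides of one shared core have been measured in an assay on CHO cells, read by calcium flux; on this read-out higher numbers stand for weaker inhibition and lower numbers for stronger inhibition. Compound 1 `CC(C)(C)c1ccc(NC(=O)c2csc(Cc3c(Cl)cccc3Cl)n2)cc1` gives 300 nM, and compound 3 `O=C(Nc1ccc(C(F)(F)F)cc1)c1csc(Cc2c(Cl)cccc2Cl)n1` gives 88 nM. Compound 2 `O=C(Nc1ccccc1)c1csc(Cc2c(Cl)cccc2Cl)n1` reaches only the limit of this assay, > 4000 nM, so for compound 2 a limit is known and no number. That limit is the limit of > 4000 nM in this assay, at which 1 of the 3 values shown sits. Among the measured steps, the unsubstituted ring proved weakest: an at least 13-fold higher number from compound 1 to compound 2 (1.12 log units; beyond the scatter), and an at least 45-fold lower number from compound 2 to compound 3 (1.65 log units; beyond the scatter), while a 3.4-fold lower number from compound 1 to compound 3 (0.53 log units; beyond the scatter).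

Compound 4 `O=C(Nc1ccccc1Br)c1csc(Cc2c(Cl)cccc2Cl)n1` differs from compound 2 in one place: bromo in place of hydrogen on an aromatic carbon. Among the compounds with values here, the two measured steps away from compound 2 both put a group on an aromatic carbon of that ring and both were large, but the bromo of compound 4 enters ortho to a large group, a place for which no measured step exists, and bromo is a smaller entering group than tert-butyl or trifluoromethyl. A gain from compound 2 is therefore expected, but a smaller one; compound 4 is estimated at 2000 nM, with a range from 500 nM to 8000 nM. That estimate means a step of an at least 2.0-fold lower number from compound 2 to compound 4 (0.30 log units; that floor lies within the scatter).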

Compound 4, half-maximal inhibitory concentration: > 4000 nM
Compound 4: a limit, no number; the forecaster's own chance of this, stated with the estimate: 40%; middle value at least 2.0-fold (0.30 log units) away from the limit.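

Compound 4 ends at a limit of this assay, as compound 2 does, so no step between compound 2 and compound 4 can be read: the limit of > 4000 nM in this assay, at which 2 of the 4 values shown sit.

The compounds shown leave open whether bromo in place of hydrogen changes the inhibition at all.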